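Dropping a Chloro Group From a Phenyl Ether

This account rests on a few compounds, and the source may have more. Where it says the series, first, only, none or still open, it means among the compounds named here.

Of the compounds shown here, three built on a shared bicyclic amine core have been measured in an in vitro assay on SH-EP1 cells for displacement of a labelled ligand from Neuronal acetylcholine receptor; alpha4/beta2 (Homo sapiens); a lower number here means a stronger inhibitor, a higher number a weaker inhibitor. Compound 1 `Fc1ccc(C2=CC3CNCC(C2)C3)cn1` gives 0.4 nM in this assay. Compound 3 `C1=C(c2cccnc2)C[C@@H]2CNC[C@H]1C2` gives 0.1 nM in this assay. Compound 2 `Clc1cccc(Oc2cncc(C3=CC4CNCC(C3)C4)c2)c1` gives 1 nM in this assay, the highest number of the three, and its distance to each of the other two compounds lies beyond the usual scatter, so it is the weakest binder in this small set.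

Compound 4 `C1=C(c2cncc(Oc3ccccc3)c2)CC2CNCC1C2` is compound 2 with a single change: hydrogen in place of chloro on an aromatic carbon. Cut one bond further out, the change reads 3-chlorophenyl to phenyl; the rest of the molecule, including the ether link to the pyridine and the amine core, is untouched.

For the measured compounds named here, no pair of measured compounds differs by this kind of change, so the data give no direct guide to its effect. Since a single chlorine atom is a small part of a large molecule, the expected step from compound 2 to compound 4 in this assay is a 1.2-fold higher number from compound 2 to compound 4 (0.08 log units; within the scatter), which is not beyond the scatter in either direction. Compound 4 is therefore estimated at 1.2 nM in this assay, with a range from 0.4 nM to 3.5 nM.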

Compound 4, inhibition constant: 0.7 nM
Compound 4: the middle estimate sits 1.7-fold (0.23 log units) above what was measured, and the stated range covers the measured number.
By their numbers in this assay, from the lowest: compound 3; then compounds 1, 4 and 2 (each within the scatter of the next, the first and the last beyond it).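

Going from 3-chlorophenyl to phenyl in this assay gives a 1.4-fold lower number from compound 2 to compound 4 (0.15 log units; within the scatter), so the two compounds cannot be told apart in this read-out. For the compounds shown here, this pair is the first in the set to differ in one place only, which makes it the first direct reading of any single change on this scaffold: at this aromatic carbon, chloro and hydrogen give binding numbers that lie within the usual scatter of each other, and the chlorine atom brings no detectable gain or loss here. Nothing in the data shown explains why the swap leaves the number within the scatter.

On these data alone, this one pair shows only that chloro and hydrogen can stand in for each other at this place, so it remains open whether a methoxy group, an amine or a carboxylic acid on the same carbon would also leave the number within the scatter. As far as these compounds go, it also remains open whether chloro placed on a different carbon of that ring would give the same result, or whether the phenyl ring can carry any larger group at all.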